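Antagonist efficacy series: heteroaryl exchange on the shared core

This account rests on a few compounds, and the source may have more. Where it says the series, first, only, none or still open, it means among the compounds named here.

Of the compounds shown here, two carry measured values so far. Compound 1 `O=C(O)Cc1sc(Cc2ccccc2)nc1-c1ccc(Cl)cc1` gives 50% in an in vitro functional assay on HEK285-7 cells for antagonist activity at prostaglandin D2 receptor 2 (Homo sapiens), read by BRET and beta-arrestin recruitment; a lower number here means a smaller maximal response, a higher number a larger maximal response. Compound 2 `O=C(O)Cc1sc(C(c2ccc(F)cc2)c2ccc(F)cc2)nc1-c1cc(F)cc(F)c1` gives 80% in this assay, the higher of the two numbers, with compound 1 sitting lower by a margin beyond the usual scatter. For the measured compounds named here, no two measured compounds differ in a single place, so no measured step is available as a guide. Compound 3 `Nc1cc(-c2nc(C(c3ccc(F)cc3)c3ccc(F)cc3)sc2CC(=O)O)cc(F)n1` is not yet measured in this assay and differs from compound 2 in one place (2-amino-6-fluoropyridin-4-yl in place of 3,5-difluorophenyl on an aromatic carbon); the exchange sits next to the ring nitrogen of the shared core, two ring bonds from the ring sulfur. Going by the values given here, with no measured step of this kind to rest on, the expected step from compound 2 to compound 3 is a number 10 percentage points lower from compound 2 to compound 3 (within the scatter), a modest fall that may well stay within the scatter. Compound 3 is estimated to give 70% in this assay, with a range from 45% to 95%.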

Compound 3, largest response reached (reported as efficacy), in percent of the reference or control that the assay uses: 30%
Compound 3: the middle estimate sits 40 percentage points above what was measured; measured number below the stated range.
By their numbers in this assay, from the lowest: compound 3; then compound 1; then compound 2.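

In this assay, for the compounds shown here, the exchange of 3,5-difluorophenyl for 2-amino-6-fluoropyridin-4-yl on the aromatic carbon next to the ring nitrogen gives a number 50 percentage points lower from compound 2 to compound 3 (beyond the scatter) and forms the only single-place step. The maximal response therefore depends strongly on which aromatic group sits at this position, even though both groups count the same number of heavy atoms and carry no net charge, while the entering group brings a hydrogen-bond donor and hydrogen-bond acceptors that the leaving group lacks. Nothing on hand accounts for the size of this step.

The compounds shown leave open whether the step follows the amino group, the pyridine ring nitrogen or the loss of a fluorine, and a plain pyridin-4-yl or a 3-amino-5-fluorophenyl group would separate these. As far as these compounds go, whether the same exchange has a similar effect alongside the benzyl group of compound 1 also remains open.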